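The source may report more compounds than this note shows. Statements on the series, on what has been measured and on what is new or still open speak of the compounds shown alone.

Three compounds have been measured in a functional assay on A549 cells (Homo sapiens) for inhibition, tested at 100 uM; a higher number here means a stronger effect of the compound at the concentration tested, a lower number a weaker effect:

Compound 1 `COc1ccc2c(c1)c(-c1cc(C(F)(F)F)ccn1)cn2S(=O)(=O)c1ccc(C)cc1` gives 35.9%.
Compound 2 `Cc1ccc(S(=O)(=O)n2cc(-c3cc(C(F)(F)F)cc(-c4cn(S(=O)(=O)c5ccc(C)cc5)c5ccccc45)n3)c3ccccc32)cc1` gives 69.3%.
Compound 3 `COc1ccc2c(-c3cc(C(F)(F)F)cc(-c4cn(S(=O)(=O)c5ccc(C)cc5)c5cc(OC)ccc45)n3)cn(S(=O)(=O)c3ccc(C)cc3)c2c1` gives 45.7%.

Compound 1 holds the lowest of the three numbers. Its nearest neighbour is compound 3, whose number lies within the scatter of that of compound 1, so the two cannot be told apart; compound 2 stands clearly higher, beyond the scatter. No pair of these compounds differs in only one place, so no single step between measured compounds can be read off.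

Compound 4 `Cc1ccc(S(=O)(=O)n2cc(-c3cc(C(F)(F)F)ccn3)c3cc(OCc4ccccc4)ccc32)cc1` has not been measured. It differs from compound 1 in one place: phenyl in place of hydrogen on a saturated chain carbon bound to an oxygen on an aromatic ring. Nothing in the measured set isolates this change, so the direction of the step rests only on compound 1 and on the general level of the others. The step from compound 1 to compound 4 in this assay is expected to be small and upward, a number 8.1 percentage points higher from compound 1 to compound 4 (within the scatter), and may not exceed the scatter. For compound 4 in this assay the estimate is 44%, with a range from 25% to 65%.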

Compound 4, a percentage reported as inhibition, at one concentration (the size of the read-out at that concentration, not a potency): 35.9%
Beside the measured number, compound 4's estimate is 8.1 percentage points above it, and the stated range covers the measured number.
By their numbers in this assay, from the lowest: compounds 1, 4 and 3 (each within the scatter of the next); then compound 2.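

Among the compounds shown here, the first step that can be read in one place is the change from methoxy to benzyloxy, which in this assay gives no change at the digits printed from compound 1 to compound 4 (within the scatter). It shows that, on this saturated chain carbon bound to an oxygen on an aromatic ring, phenyl in place of hydrogen leaves the read-out at this single concentration unmoved, so this added ring does not separate the two compounds here. No measured evidence bears on why the step is flat.

As far as these compounds go, whether other groups at this place would also leave the number unmoved remains open, for instance a longer chain, an amine or a carboxylic acid on the same carbon. From the compounds shown here alone, it is also open whether methoxy to benzyloxy would give the same result on compound 3, and the read-out at one concentration says nothing about potency.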